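The compounds below may be only part of what the source reports. "The series", "measured", "known", "first", "only" and "open" are said of these compounds alone.

Compound 3 `CN(C(=O)c1ccc(Br)cc1)c1ccc2[nH]c(-c3n[nH]c4ccccc34)cc2n1` carries the shared core with a 4-bromophenyl on the carbonyl carbon. Going by the values given here, in a functional assay on SMMC-7721 cells (Homo sapiens) for antiproliferative activity, read by MTT assay, with a stated time of 72 h (a lower number here means a stronger inhibitor, a higher number a weaker inhibitor), compound 3 gives 3460 nM, the second highest of the three numbers known: nearest stands compound 2 `CN(C(=O)c1ccc(Cl)cc1)c1ccc2[nH]c(-c3n[nH]c4ccccc34)cc2n1`, which gives 2420 nM, and furthest compound 1 `CN(C(=O)CCc1ccccc1)c1ccc2[nH]c(-c3n[nH]c4ccccc34)cc2n1`, which gives 20900 nM. The change to compound 4 `CN(C(=O)c1ccc([N+](=O)[O-])cc1)c1ccc2[nH]c(-c3n[nH]c4ccccc34)cc2n1` is nitro in place of bromo on an aromatic carbon, para to a large group. Among the compounds with values here, the only step that bears on a swap at this aromatic carbon is a 1.4-fold higher number from compound 2 to compound 3 (0.16 log units; within the scatter), within the scatter; the steps of an 8.6-fold lower number from compound 1 to compound 2 (0.94 log units; beyond the scatter) and a 6.0-fold lower number from compound 1 to compound 3 (0.78 log units; beyond the scatter) concern the aryl against phenethyl, not the para group. Within the data shown here, no nitro analogue has been measured, so compound 4 is expected to stay close to compound 3, with a 1.2-fold lower number from compound 3 to compound 4 (0.06 log units; within the scatter) and an estimate of 3000 nM between 900 nM and 10000 nM.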

Compound 4, half-maximal inhibitory concentration: 18400 nM
Compound 4: the middle estimate sits 6.1-fold (0.79 log units) below what was measured; measured number above the stated range.
By their numbers in this assay, from the lowest: compounds 2 and 3 (each within the scatter of the next); then compounds 4 and 1 (each within the scatter of the next).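

Nitro on this aromatic carbon separates itself from the halogens in this assay, with a 5.3-fold higher number from compound 3 to compound 4 (0.73 log units; beyond the scatter) and a 7.6-fold higher number from compound 2 to compound 4 (0.88 log units; beyond the scatter), whereas bromo and chloro stayed within the scatter of each other. The 4-nitrophenyl group also gives up the gain that the 4-chlorophenyl and 4-bromophenyl groups held over phenethyl, with a 1.1-fold lower number from compound 1 to compound 4 (0.06 log units; within the scatter), which is within the scatter. Nothing available accounts for this drop. On these data alone, whether an amine, a methoxy group or a carboxylic acid on this carbon would stay with the halogens or fall with nitro remains open, as does the result with plain hydrogen there.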